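Terminal piperazine substituent swap in an aryl ketone series

The source may hold more compounds than are shown below. What is called first, only, known or untested is meant among the compounds shown, and "the series" means these compounds.

Measured compounds:
Compound 1 `CCN(CC)c1ccc2cc(C(=O)c3ccc(N4CCN(C(=O)CN5CCN(C(=O)/C=C/c6ccccc6)CC5)CC4)cc3)oc2c1` — 9450 nM
Compound 2 `CCN(CC)c1ccc2cc(C(=O)c3ccc(N4CCN(C(=O)CN5CCN(Cc6ccc(F)c(F)c6)CC5)CC4)cc3)oc2c1` — 5440 nM

Going by the values given here, in a functional assay on A549 cells (Homo sapiens) for cytotoxicity, read by MTT assay, with a stated time of 48 h (on this read-out higher numbers stand for weaker inhibition and lower numbers for stronger inhibition), compound 2 holds the lowest of the two numbers; its only neighbour is compound 1, and the gap is one a 1.7-fold lower number from compound 1 to compound 2 (0.24 log units; within the scatter), so the two compounds cannot be separated on these data.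

Compound 3 `CCOC(=O)CN1CCN(CC(=O)N2CCN(c3ccc(C(=O)c4cc5ccc(N(CC)CC)cc5o4)cc3)CC2)CC1` is not yet measured. Relative to compound 2 the change is ethoxycarbonyl in place of 3,4-difluorophenyl on a saturated chain carbon bound to an amine nitrogen in a ring; in the wider reading, 3,4-difluorobenzyl to (ethoxycarbonyl)methyl.

Among the compounds with values here, the one measured step, a 1.7-fold lower number from compound 1 to compound 2 (0.24 log units; within the scatter), concerns the same amine nitrogen in a ring but exchanges different groups, and it stayed within the scatter. Within the data shown here, no step with an ethoxycarbonyl group exists. The expectation for compound 3 is therefore a step of a 1.3-fold higher number from compound 2 to compound 3 (0.11 log units; within the scatter) in this assay, with no direction that can be defended beyond the scatter, and a wide range to reflect the lack of a closer precedent. Compound 3 is estimated at 7000 nM, with a range from 2500 nM to 20000 nM.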

Compound 3, half-maximal inhibitory concentration: > 40000 nM
Compound 3: only a limit was reported (the forecaster's own chance of this, stated with the estimate: 10%); middle value at least 5.7-fold (0.75 log units) from the limit.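

In this assay compound 3 gives a limit of the assay and not a number: the limit of > 40000 nM in this assay, at which 1 of the 3 values shown sits.

Until now the substituent on this amine nitrogen in a ring had shown no step beyond the scatter, but the (ethoxycarbonyl)methyl group gives one against each of the other two groups: an at least 7.3-fold higher number from compound 2 to compound 3 (0.86 log units; beyond the scatter) and an at least 4.2-fold higher number from compound 1 to compound 3 (0.62 log units; beyond the scatter). Going by these compounds alone, the position is therefore not indifferent to what it carries: among the three compounds, 3,4-difluorobenzyl and (2-phenylethenyl)carbonyl both bring a six-membered aromatic ring of carbon only and stay within the scatter of each other, while the group without a ring stands apart, with no compound here going against that reading.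

The three compounds leave open whether the weaker read-out goes with the absence of the aromatic ring or with the presence of the ethoxycarbonyl group, as the two change together in this step. A benzyl group without fluorine, or a carboxylic acid or a simple alkyl chain in place of the ethoxycarbonyl on the saturated chain carbon, would be needed to separate the two readings.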